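The source may report more compounds than this note shows. Statements on the series, on what has been measured and on what is new or still open speak of the compounds shown alone.

Measured compounds and their numbers in a functional assay on CCRF-CEM cells (Homo sapiens) for inhibition; on this read-out higher numbers stand for an effect only at larger amounts of compound and lower numbers for an effect already at smaller amounts:
- compound 1 `CC1(C)Oc2ccc(C#N)cc2[C@H](NCc2ccccc2)[C@H]1O` gives 59100 nM
- compound 2 `CC(C)(C)OC(=O)CN[C@H]1c2cc(C#N)ccc2OC(C)(C)[C@@H]1O` gives 46800 nM
- compound 3 `CC(C)(C)OC(=O)CN(Cc1ccccc1)[C@H]1c2cc(C#N)ccc2OC(C)(C)[C@@H]1O` gives 2430 nM

Compound 2 stands second highest of the three numbers; its nearest neighbour is compound 1, at a 1.3-fold lower number from compound 1 to compound 2 (0.10 log units; within the scatter), and its furthest is compound 3, at a 19-fold lower number from compound 2 to compound 3 (1.28 log units; beyond the scatter). The large drop to compound 3 comes with a second substituent on the amine nitrogen, and the same is seen in a 24-fold lower number from compound 1 to compound 3 (1.39 log units; beyond the scatter).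

Compound 4 `CN[C@H]1c2cc(C#N)ccc2OC(C)(C)[C@@H]1O` differs from compound 2 by hydrogen in place of tert-butoxycarbonyl on a saturated chain carbon bound to an amine nitrogen. Among the compounds with values here, no measured step puts hydrogen in place of the group on that chain carbon. Within the data shown here, the only step that bears on the substituent on that chain carbon is a 1.3-fold lower number from compound 1 to compound 2 (0.10 log units; within the scatter), where exchanging phenyl for tert-butoxycarbonyl left the number within the scatter. The amine nitrogen of compound 4 keeps a single substituent, as in compound 1 and compound 2, so the large steps to compound 3 do not apply. The change from compound 2 to compound 4 is therefore expected to give no step beyond the scatter in this assay, with the remaining uncertainty leaning toward a somewhat higher number, since the group on that carbon shrinks to a hydrogen.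

Compound 4 is estimated at 60000 nM, with a range from 25000 nM to 150000 nM, which corresponds to an expected step of a 1.3-fold higher number from compound 2 to compound 4 (0.11 log units; within the scatter).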

Compound 4, half-maximal effective concentration: 1430000 nM
Compound 4: the middle estimate sits 24-fold (1.38 log units) below what was measured, and the stated range ends below it.
By their numbers in this assay, from the lowest: compound 3; then compounds 2 and 1 (each within the scatter of the next); then compound 4.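

In this assay, within the data shown here, the earlier compounds made the saturated chain carbon bound to an amine nitrogen look undemanding, since exchanging phenyl for tert-butoxycarbonyl gave only a small step (a 1.3-fold lower number from compound 1 to compound 2 (0.10 log units; within the scatter)). Hydrogen at the same place does not fit that picture: removing tert-butoxycarbonyl gives a large step (a 31-fold higher number from compound 2 to compound 4 (1.49 log units; beyond the scatter)), and removing phenyl gives one of similar reach (a 24-fold higher number from compound 1 to compound 4 (1.38 log units; beyond the scatter)), so among these compounds the number depends on whether that carbon carries a group at all far more than on which of the two groups it carries. No available measurement accounts for this loss.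

The compounds shown leave open how small a group on that carbon can be before the number rises, as a methyl, an ethyl or a short alkyl chain would show, and whether a carboxylic acid or an amide in place of tert-butoxycarbonyl would stay with phenyl and tert-butoxycarbonyl or move toward hydrogen. Also open, going by these compounds, is whether benzyl on the amine nitrogen of compound 4 would lower the number as it does from compound 2 to compound 3.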